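A few compounds are considered here, and "the series" means these few. Any claim that something is new, unique, unknown or untested is made for them only; others in the source may bear on it.

In an ADME assay on CRL8155 cells (Homo sapiens) for cytotoxicity, read by resazurin assay, with a stated time of 72 h (on this read-out lower numbers stand for an effect already at smaller amounts and higher numbers for an effect only at larger amounts of compound), compound 1 `NCCCCNC(=O)Nc1nc2ccc(C(=O)c3ccccc3)cc2[nH]1` gives only a limit, > 30000 nM. Compound 2 `O=C(NCCC1CCNCC1)Nc1nc2ccc(C(=O)c3ccccc3)cc2[nH]1` likewise stops at a limit, > 30000 nM. The step that the two limits leave unreadable from compound 1 to compound 2 is thus not readable in size. Compound 3 `CN1CCC(CCn2c(N)nc3ccc(C(=O)c4ccccc4)cc32)CC1` also sits at a limit, > 30000 nM, so its standing among the three cannot be separated on these numbers: every value shown sits at the limit of > 30000 nM in this assay, at which 3 of the 3 values shown sit. Compound 4 `CN1CCC[C@@H]1Cn1c(N)nc2ccc(C(=O)c3ccccc3)cc21` differs from compound 3 by 1-methylpyrrolidin-2-yl in place of (1-methylpiperidin-4-yl)methyl on a saturated chain carbon bound to an aromatic nitrogen. For the measured compounds named here, no measured step bears on this change, the only step between measured compounds being unreadable. Compound 4 is therefore expected to remain at the limit as well, the expected step being a number no higher from compound 3 to compound 4 (the limit leaves the size open). The estimated value for compound 4 is 30000 nM, with a range of 15000 nM to 60000 nM, most likely reported as a limit only.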

Compound 4, half-maximal effective concentration: > 30000 nM
Compound 4 gave a limit, no number; the forecaster's own chance of this, stated with the estimate: 85%; the middle value sits exactly at the limit.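

For the compounds shown here, compound 3 and compound 4 each give only a limit in this assay, so no step between them can be read. The compounds shown leave open whether 1-methylpyrrolidin-2-yl in place of (1-methylpiperidin-4-yl)methyl changes the half-maximal effective concentration at all.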